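The compounds below may be only part of what the source reports. "The series", "measured", "known", "first", "only" and "open" are said of these compounds alone.

In a functional assay on K562 cells (Homo sapiens) for antiproliferative activity, read by MTT assay, with a stated time of 48 h (a lower number here means a stronger inhibitor, a higher number a weaker inhibitor), compound 1 (`CCN(CC)Cc1ccc2c(c1O)-c1ccc(cc1O)CCc1ccc(O)c(c1)Oc1ccc(cc1)CC2`) gives 7860 nM. Compound 2 (`Oc1ccc2cc1Oc1ccc(cc1)CCc1ccc(CN3CCCCC3)c(O)c1-c1ccc(cc1O)CC2`) gives 5880 nM, and a 1.3-fold lower number from compound 1 to compound 2 (0.13 log units; within the scatter) separates the two. Compound 3 (`CN1CCN(Cc2ccc3c(c2O)-c2ccc(cc2O)CCc2ccc(O)c(c2)Oc2ccc(cc2)CC3)CC1`) gives 3310 nM, with a 2.4-fold lower number from compound 1 to compound 3 (0.38 log units; beyond the scatter). Compound 1 therefore stands clear of compound 3 but not of compound 2, while a 1.8-fold lower number from compound 2 to compound 3 (0.25 log units; within the scatter) leaves those two unresolved.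

Compound 4 (`CCN(CC)Cc1cc2cc(c1O)Oc1ccc(cc1)CCc1ccc(CN(CC)CC)c(O)c1-c1ccc(cc1O)CC2`) keeps the core and side chain of compound 1 and carries one further change: (diethylamino)methyl in place of hydrogen on an aromatic carbon. The new (diethylamino)methyl sits in place of hydrogen on an aromatic carbon, ortho to a hydroxy group.

The measured steps bear on this only indirectly. All three exchange the amine on the existing chain, and none adds a group at a new place. The largest of them, a 2.4-fold lower number from compound 1 to compound 3 (0.38 log units; beyond the scatter), is modest, so the data suggest no firm direction, and no step beyond the scatter is expected in this assay. For compound 4 the estimated value is 5500 nM, within an expected range from 2000 nM to 14000 nM. The expected change is a 1.4-fold lower number from compound 1 to compound 4 (0.16 log units; within the scatter).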

Compound 4, half-maximal inhibitory concentration: 1860 nM
Compound 4: the middle estimate sits 3.0-fold (0.47 log units) above what was measured; measured number below the stated range.
By their numbers in this assay, from the lowest: compounds 4, 3, 2 and 1 (each within the scatter of the next, the first and the last beyond it).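

The earlier compounds shown here only exchanged the amine on the existing chain, whereas compound 4 places a new group on the core. In this assay, (diethylamino)methyl in place of hydrogen on an aromatic carbon, ortho to a hydroxy group, gives a 4.2-fold lower number from compound 1 to compound 4 (0.63 log units; beyond the scatter) and so moves the number beyond the scatter, though the step is modest. This position therefore accepts the added (diethylamino)methyl with a stronger result in this assay, and the change at this new place counts for more here than the amine exchanges did. Nothing in the available data explains this shift.

On these data alone, it remains open whether a morpholin-4-ylmethyl group or a carboxylic acid at this position would move the number in the same direction. Also open, as far as these compounds go, is whether the step at this position depends on the amine carried by the existing chain.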